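Cytotoxicity Limits Across Three Measured Compounds and One Candidate

The source may hold more compounds than are shown below. What is called first, only, known or untested is meant among the compounds shown, and "the series" means these compounds.

Measured in an ADME assay on S2 cells (Drosophila melanogaster) for cytotoxicity, read by MTT assay; a lower number here means that less compound is needed, a higher number that more compound is needed for the effect:
compound 1 `COC(=O)/C=C/[C@H]1C[C@@H](O)[C@@H](O)C1` — compound 1 gives only the assay limit > 350000 nM
compound 2 `O=C(/C=C/[C@H]1C[C@@H](O)[C@@H](O)C1)Nc1ccc(Cl)cc1` — compound 2 gives only the assay limit > 180000 nM
compound 3 `O=C(/C=C/[C@H]1C[C@@H](O)[C@@H](O)C1)Nc1ccc(Cl)c(Cl)c1` — compound 3 gives only the assay limit > 160000 nM

Compound 2 stands at a limit rather than at a number, as the limit of > 180000 nM in this assay, at which 1 of the 3 values shown sits, shows. Going by the values given here, the two other values shown are limits as well, the limit of > 160000 nM in this assay, at which 1 of the 3 values shown sits, and (the limit of > 350000 nM in this assay, at which 1 of the 3 values shown sits), so no compound in this set has a measured number in this assay.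

Compound 4 `COc1ccc(NC(=O)/C=C/[C@H]2C[C@@H](O)[C@@H](O)C2)cc1` differs from compound 2 in one place: methoxy in place of chloro on an aromatic carbon. Among the compounds with values here, the only measured step that touches this part of the structure is a step that the two limits leave unreadable from compound 2 to compound 3; it is a step whose two limits leave its size unreadable, so it gives no direction and no size to carry over. Within the data shown here, what the three values together show is that every compound tested so far sits at a limit in this assay.

On that basis compound 4 is expected to sit at a limit too, with an estimate of 200000 nM and a range from 100000 nM to 400000 nM. The estimated step that the limit leaves unreadable from compound 2 to compound 4 is expected to be none beyond the scatter, most likely reported again as a limit.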

Compound 4, half-maximal effective concentration: > 180000 nM
Compound 4: no number, only a limit; the forecaster's own chance of this, stated with the estimate: 85%; the middle value does not contradict the limit.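

In this assay compound 4 gives only a limit, > 180000 nM. Compound 2 also stands at a limit, so no step can be read between compound 2 and compound 4. The compounds shown leave open where any of them would give a measured number, and whether methoxy and chloro differ in this assay.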